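The source may report more compounds than this note shows. Statements on the series, on what has been measured and on what is new or still open speak of the compounds shown alone.

Measured so far in an assay on isolated protein (spleen, strain Sprague-Dawley) for antagonist activity at Alpha-1B adrenergic receptor (Rattus norvegicus), with a stated time of 20 min; a higher number here means weaker binding, a lower number tighter binding:
- compound 1 `COc1ccccc1N1CCN(CCCNC(=O)c2ccc3[nH]ccc3c2)CC1`; in this assay compound 1 gives 123 nM
- compound 2 `COc1ccccc1N1CCN(CCCNC(=O)CCCc2c[nH]c3ccccc23)CC1`; in this assay compound 2 gives 95.5 nM

Compound 1 stands with the higher of the two numbers, but compound 2 sits within the scatter of it, so the two are not ordered against each other and neither can be called the tighter binder on these data.

Compound 3 `COc1ccccc1N1CCN(CCCNC(=O)c2cc3cc(O)ccc3[nH]2)CC1` has not been measured. Against compound 1 its structure shows one change, (5-hydroxy-1H-indol-2-yl in place of 1H-indol-5-yl on a carbonyl carbon), with the amide and the rest of the shared core left as they are. For the measured compounds named here, no measured pair in the set differs in a single place, so there is no measured step to lean on for this change; what is expected rests only on the two values above and on the change itself.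

The step from compound 1 to compound 3 is expected to be a 1.8-fold lower number from compound 1 to compound 3 (0.24 log units; within the scatter), toward a lower number, and of a size not far beyond the scatter. For compound 3 the expected value in this assay is 70 nM, with a range from 20 nM to 250 nM.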

Compound 3, dissociation constant: 155 nM
Estimate against measurement, compound 3: 2.2-fold (0.35 log units) below; the measured number falls inside the stated range.
By their numbers in this assay, from the lowest: compounds 2, 1 and 3 (each within the scatter of the next).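

In this assay, for the compounds shown here, placing 5-hydroxy-1H-indol-2-yl where 1H-indol-5-yl stood on a carbonyl carbon whose other neighbours are amide-type nitrogen gives a 1.3-fold higher number from compound 1 to compound 3 (0.10 log units; within the scatter), the first single-place step, and the assay does not separate the two groups. The entering group carries an added oxygen and differs from the leaving group in both the hydroxy and the point of attachment, 2-yl against 5-yl, so this one step holds two structural differences and cannot be divided between them. No measurement here bears on why the two groups give numbers within the scatter of each other.

On these data alone, what each of those two differences contributes alone remains open, and 1H-indol-2-yl without the hydroxy on the same carbonyl carbon would separate them. Also open, as far as these compounds go, is how the number responds to other groups at the same place, such as 5-methoxy-1H-indol-2-yl, or to a carboxylic acid in place of the hydroxy, and whether a longer chain on the amide nitrogen changes the picture.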